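The source may hold more compounds than are shown below. What is called first, only, known or untested is meant among the compounds shown, and "the series" means these compounds.

Working notes on the series. Compound 1 `C=CCOc1ccc(C(=O)Nc2ccccn2)cc1` gives 61400 nM in an in vitro assay on HEK-tsA201 cells for antagonist activity at Neuronal acetylcholine receptor; alpha3/beta4 (Homo sapiens), read by fluorescence and calcium flux; on this read-out higher numbers stand for weaker inhibition and lower numbers for stronger inhibition. Compound 2 `C=CCOc1ccc(C(=O)Nc2cccc(Br)n2)cc1` gives 65500 nM in this assay; the step of a 1.1-fold higher number from compound 1 to compound 2 (0.03 log units; within the scatter) records a bromo in place of hydrogen on an aromatic carbon. Compound 3 `CCCOc1ccc(C(=O)Nc2cccc(Br)n2)cc1` is reported in this assay only as a limit of the assay, > 100000 nM. Compound 3 therefore stands at the limit of > 100000 nM in this assay, at which 1 of the 3 values shown sits, the weakest point the numbers shown can record. The step of an at least 1.5-fold higher number from compound 2 to compound 3 (0.18 log units; that floor lies within the scatter) is an ethyl in place of vinyl on a saturated chain carbon bound to an oxygen on an aromatic ring.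

Compound 4 `CCCOc1ccc(C(=O)Nc2cccc(N3CCCCC3)n2)cc1` differs from compound 3 by piperidin-1-yl in place of bromo on an aromatic carbon. Of the measured steps only the bromo substitution touches this aromatic carbon, and a 1.1-fold higher number from compound 1 to compound 2 (0.03 log units; within the scatter) sat within the scatter; the chain step an at least 1.5-fold higher number from compound 2 to compound 3 (0.18 log units; that floor lies within the scatter) reaches only a floor. For the measured compounds named here, no measured step in this assay is large, so no change beyond the scatter is expected from the step of an at least 1.1-fold lower number from compound 3 to compound 4 (0.04 log units; that floor lies within the scatter). Compound 4 is therefore estimated at 90000 nM in this assay, with a range from 20000 nM to 400000 nM, and a limit is again likely.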

Compound 4, half-maximal inhibitory concentration: > 100000 nM
Compound 4: no number, only a limit; the forecaster's own chance of this, stated with the estimate: 55%; middle value at least 1.1-fold (0.04 log units) from the limit.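

In this assay compound 4 is reported only as a limit, > 100000 nM. For the compounds shown here, compound 3 is likewise reported only as a limit, so no step between the two can be read. The compounds shown leave open how piperidin-1-yl and bromo compare on the shared core.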